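The source may report more compounds than this note shows. Statements on the series, on what has been measured and on what is new or still open speak of the compounds shown alone.

Compound 3 `O=C(Nc1ccc(Oc2ccnc3[nH]ccc23)cc1)c1nnn(-c2ccccc2F)c1C(F)(F)F` gives 210 nM in a functional assay on A549 cells (Homo sapiens) for cytotoxicity, read by MTT assay, with a stated time of 72 h; a lower number here means a stronger inhibitor, a higher number a weaker inhibitor. Compound 2 `Cc1c(C(=O)Nc2ccc(Oc3ccnc4[nH]ccc34)cc2)nnn1-c1ccccc1F` gives 320 nM and compound 1 `Cc1c(C(=O)Nc2ccc(Oc3ccnc4[nH]ccc34)c(F)c2)nnn1-c1ccccc1F` gives 390 nM, and both sit within the scatter of compound 3, so the three numbers cannot be told apart. Compound 4 `O=C(Nc1ccc(Oc2ccnc3[nH]ccc23)cc1)c1nnn(-c2ccc(Cl)c(C(F)(F)F)c2)c1C(F)(F)F` differs from compound 3 by 4-chloro-3-(trifluoromethyl)phenyl in place of 2-fluorophenyl on an aromatic nitrogen. Among the measured compounds shown here, no measured step touches this group: a 1.2-fold lower number from compound 1 to compound 2 (0.09 log units; within the scatter) and a 1.5-fold lower number from compound 2 to compound 3 (0.18 log units; within the scatter) were both small and concern other parts of the shared core, so they give no direct guide for the group on the aromatic nitrogen. With nothing to point either way, a step no larger than the scatter is expected, a 1.0-fold higher number from compound 3 to compound 4 (0.02 log units; within the scatter). Compound 4 is therefore estimated at 220 nM in this assay, within a range from 70 nM to 700 nM.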

Compound 4, half-maximal inhibitory concentration: 2340 nM
Beside the measured number, compound 4's estimate is 11-fold (1.03 log units) below it, outside the stated range (above it).
By their numbers in this assay, from the lowest: compounds 3, 2 and 1 (each within the scatter of the next); then compound 4.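

Among the compounds shown here, the group on the aromatic nitrogen proves far more sensitive than the places changed earlier: in this assay, replacing 2-fluorophenyl with 4-chloro-3-(trifluoromethyl)phenyl gives an 11-fold higher number from compound 3 to compound 4 (1.05 log units; beyond the scatter), the only step here beyond the scatter. The weakening appears although the aromatic ring stays and the count of hydrogen-bond donors and acceptors does not change. Nothing available explains this loss.

This single pair leaves open whether the chloro group, the added trifluoromethyl group or the absent 2-fluoro substituent carries the step. From the compounds shown here alone, how an amine or a carboxylic acid on this phenyl ring would read out also remains open.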